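Half-life in liver microsomes: a triazolylamino replacement

The source may hold more compounds than are shown below. What is called first, only, known or untested is meant among the compounds shown, and "the series" means these compounds.

Measured so far:
compound 1, `CC(C)C(c1ccc(-c2ccc3cccc(F)c3c2)[nH]c1=O)N1CCCCC1=O`, 0.183 h;
compound 2, `CC(C)C(c1ccc(-c2ccc3cccc(F)c3c2)[nH]c1=O)N1CCN/C1=N\C#N`, 0.632 h;
compound 3, `CC(C)C(/C=C1/CCNC1=O)c1ccc(-c2ccc3cccc(F)c3c2)[nH]c1=O`, 0.987 h.

The three compounds share one core and differ only in the group attached on a saturated chain carbon bound to an aromatic carbon and a saturated chain carbon. In an ADME assay on microsomes from liver (Homo sapiens) for metabolic stability (a higher number here means that the compound lasts longer, a lower number that the compound disappears faster), compound 3 gives the highest of the three numbers. Its nearest neighbour is compound 2, and the gap between them is within the scatter, as a 1.6-fold higher number from compound 2 to compound 3 (0.19 log units; within the scatter) shows. The gap to compound 1 is larger: a 5.4-fold higher number from compound 1 to compound 3 (0.73 log units; beyond the scatter), and likewise a 3.5-fold higher number from compound 1 to compound 2 (0.54 log units; beyond the scatter).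

Compound 4, `CC(C)C(Nc1nnc[nH]1)c1ccc(-c2ccc3cccc(F)c3c2)[nH]c1=O`, has not been measured in this assay. It differs from compound 3 at the same position that varies among the measured compounds: a group of 6 heavy atoms (2 carbon, 4 nitrogen; one five-membered aromatic ring with 3 hetero atoms) in place of a group of 7 heavy atoms (5 carbon, 1 nitrogen, 1 oxygen; one five-membered non-aromatic ring with 1 hetero atom), on a saturated chain carbon bound to an aromatic carbon and a saturated chain carbon.

Among the measured compounds shown here, the steps that bear on this change are those at the same position. For the measured compounds named here, of those, only the steps leaving compound 1 went beyond the scatter, while the exchange between compound 2 and compound 3 did not. Going by the values given here, no measured step introduces an aromatic ring at this position, so the direction is uncertain. Compound 4 is therefore expected to land near compound 3, with a 1.2-fold lower number from compound 3 to compound 4 (0.09 log units; within the scatter) as the estimated step, most likely within the scatter. The estimate for compound 4 in this assay is 0.8 h, within a range from 0.35 h to 1.8 h.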

Compound 4, half-life: > 3 h
Compound 4: only a limit was reported; the forecaster's own chance of this, stated with the estimate: 5%; middle value at least 3.7-fold (0.57 log units) away from the limit.
By their numbers in this assay, from the lowest: compound 1; then compounds 2 and 3 (each within the scatter of the next). At a limit, above all of these: compound 4.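

In this assay, among the compounds shown here, compound 4 gives > 3 h, which is a limit of the assay and not a number, and no other compound shown sits at that limit. At this saturated chain carbon, the (4H-1,2,4-triazol-3-yl)amino group separates clearly from the two groups with a five-membered non-aromatic ring, which had stayed within the scatter of each other, with an at least 3.0-fold higher number from compound 3 to compound 4 (0.48 log units; beyond the scatter) and an at least 4.7-fold higher number from compound 2 to compound 4 (0.67 log units; beyond the scatter). Set against 2-oxopiperidin-1-yl, the same group gives an at least 16-fold higher number from compound 1 to compound 4 (1.21 log units; beyond the scatter), so the position spans a much wider range than the three earlier compounds showed, and the only aromatic ring among the groups shown stands at its upper end.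

From the compounds shown here alone, whether the longer half-life belongs to the triazole ring or to the amino nitrogen that links it to the chain carbon stays open, a question that a plain amine or an imidazolylamino group at this place would bear on. The true size of every step to compound 4 also stays open, and these steps can be read only as lower bounds: the limit of > 3 h in this assay, at which 1 of the 4 values shown sits.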